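The source may hold more compounds than are shown below. What is called first, only, known or untested is meant among the compounds shown, and "the series" means these compounds.

Compound 2 `COc1ccc(C(=O)/C=C/c2cc(-c3cc(OC)c(OC)c(OC)c3)n[nH]2)cc1OC` comes from compound 1 `COc1cc(-c2cc(/C=C/C(=O)c3ccc(N)cc3)[nH]n2)cc(OC)c1OC` by one swap: a 3,4-dimethoxyphenyl in place of 4-aminophenyl on a carbonyl carbon. In a functional assay on ACHN cells (Homo sapiens) for cytotoxicity, read by sulforhodamine B assay, with a stated time of 48 h, tested at 0.1 uM (a higher number here means a weaker effect of the compound at the concentration tested, a lower number a stronger effect), compound 1 gives 97%, and compound 2 gives 97%, so the step of no change at the digits printed from compound 1 to compound 2 (within the scatter) leaves compound 2 level with compound 1: both barely slow the cells. Compound 3 `COc1ccc(C(=O)/C=C/c2cc(-c3cc(OC)c(OC)c(OC)c3)n[nH]2)cc1` differs from compound 2 by hydrogen in place of methoxy on an aromatic carbon. Among the compounds with values here, no measured step removes a methoxy in this way, so only the weak level of compound 2 guides the guess; a step of a number 2 percentage points lower from compound 2 to compound 3 (within the scatter) is expected, and compound 3 is estimated at 95%, between 80% and 106%.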

Compound 3, a percentage reported as activity, at one concentration (the size of the read-out at that concentration, not a potency): 102%
Compound 3: middle estimate off by 7 percentage points, on the low side; measured number inside the range.
By their numbers in this assay, from the lowest: compounds 1, 2 and 3 (each within the scatter of the next).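

Dropping one methoxy from the 3,4-dimethoxyphenyl to leave 4-methoxyphenyl gives, in this assay, a number 5 percentage points higher from compound 2 to compound 3 (within the scatter), so this aromatic carbon shows no readable preference between methoxy and hydrogen. Methoxy in place of amino gives a number 5 percentage points higher from compound 1 to compound 3 (within the scatter), which means this second swap on the same ring can't be told apart either. Nothing at hand explains why these swaps read alike. On these data alone, whether a hydroxy group or a carboxylic acid on this ring would bring a clear effect stays open. So does how these compounds would separate at higher concentrations.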